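Methyl on the Ring Nitrogen: From Compound 2 to Compound 4

The compounds below may be only part of what the source reports. "The series", "measured", "known", "first", "only" and "open" are said of these compounds alone.

The study measures, in an assay on cells for displacement of a labelled ligand from adenosine receptor A2b (Homo sapiens), read by scintillation counting and radioligand binding, with a stated time of 30 min, tested at 10 uM (on this read-out higher numbers stand for more inhibition at the one concentration tested (going by the name of the read-out) and lower numbers for less inhibition), a small set of compounds sharing one core. Compound 3 `CN1CCN(c2nc(-c3cccc(O)c3)nc3[nH]cnc23)CC1` gives 27% in this assay. Compound 1 `CN1CCN(c2nc(-c3cccc(O)c3)nc3c2ncn3C)CC1` differs from it by methyl in place of hydrogen on an aromatic nitrogen and gives 47.8%, so the step is a number 20.8 percentage points higher from compound 3 to compound 1 (beyond the scatter). Compound 2 `Oc1cccc(-c2nc(N3CCCCC3)c3nc[nH]c3n2)c1` differs from compound 3 by piperidin-1-yl in place of 4-methylpiperazin-1-yl on an aromatic carbon. For compound 2 this assay reports only a limit, > 80%, as noted in the limit of > 80% in this assay, at which 1 of the 3 values shown sits. The step from compound 2 to compound 3 is therefore known only as a limit on one side: a number at least 53 percentage points lower from compound 2 to compound 3 (beyond the scatter).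

Compound 4 `Cn1cnc2c(N3CCCCC3)nc(-c3cccc(O)c3)nc21` has not been measured. It differs from compound 2 by methyl in place of hydrogen on an aromatic nitrogen, which is the same change as that from compound 3 to compound 1, made at the same place. Since compound 2 already sits at the limit and the same change on compound 3 gave the step of a number 20.8 percentage points higher from compound 3 to compound 1 (beyond the scatter), the expected step is a step that the limit leaves unreadable from compound 2 to compound 4. The estimate for compound 4 is 86%, with a likely range from 70% to 98%, most probably again reported as a limit.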

Compound 4, a percentage reported as inhibition, at one concentration (the size of the read-out at that concentration, not a potency): 29.3%
The estimate for compound 4 lay 56.7 percentage points above the measured number, and the stated range ends above it.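

In this assay, methyl in place of hydrogen on an aromatic nitrogen did not carry over from one core to the other: with piperidin-1-yl on the aromatic carbon the change gave a number at least 50.7 percentage points lower from compound 2 to compound 4 (beyond the scatter), and the two steps compare as follows: the same change on two cores in this assay, a number 20.8 percentage points higher (beyond the scatter) from compound 3 to compound 1 and a number at least 50.7 percentage points lower (beyond the scatter) from compound 2 to compound 4, at least 71.5 percentage points apart, beyond the scatter of two such steps The exchange between piperidin-1-yl and 4-methylpiperazin-1-yl likewise depended on what sits on that nitrogen, with the methylated pair giving a number 18.5 percentage points lower from compound 1 to compound 4 (beyond the scatter), and the two steps for that change compare as follows: the same change on two cores in this assay, a number at least 53 percentage points lower (beyond the scatter) from compound 2 to compound 3 and a number 18.5 percentage points higher (beyond the scatter) from compound 4 to compound 1, at least 71.5 percentage points apart, beyond the scatter of two such steps The two changes therefore do not add up across these four compounds, but this rests on a single set of four in one assay, the steps from compound 2 are fixed on one side only as its value is a limit, and the numbers give no reason for the reversal.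

The compounds shown leave open whether the reversal holds with other amines on that aromatic carbon, such as morpholin-4-yl or dimethylamino. They also leave open whether a longer chain on the ring nitrogen, such as ethyl or propyl, would behave as methyl does.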